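The compounds below may be only part of what the source reports. "The series", "measured", "known", "first", "only" and "open" are said of these compounds alone.

Measured in a functional assay on the whole organism with Rattus norvegicus as the target, at a dose of 3 mg/kg by the oral route; on this read-out lower numbers stand for a weaker effect and higher numbers for a stronger effect at the one dose given:

Compound 1 `CCCc1ccc(-c2cc(OC)cc(C(=O)Nc3nn[nH]n3)n2)cc1`: 93%
Compound 2 `CCCCc1ccc(-c2cc(OC)cc(C(=O)Nc3nn[nH]n3)n2)cc1`: 61%
Compound 3 `Cc1cc(C(=O)Nc2nn[nH]n2)nc(-c2ccccc2)c1`: 50%

Going by the values given here, the one step that can be read is a number 32 percentage points lower from compound 1 to compound 2 (beyond the scatter), which goes with methyl in place of hydrogen on a saturated chain carbon, three bonds along the chain from an aromatic carbon. Compound 3 sits lowest of the three numbers, and its distance from compound 2 as well as from compound 1 lies beyond the scatter. The difference between the core of compound 3 and the core of compound 1 is not broken down here.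

Compound 4 `CCc1cc(C(=O)Nc2nn[nH]n2)nc(-c2ccccc2)c1` is not yet measured. It differs from compound 3 by methyl in place of hydrogen on a saturated chain carbon bound to an aromatic carbon. Among the compounds with values here, this is the same kind of change as the one from compound 1 to compound 2, but not the same: there the methyl enters three bonds along the chain from an aromatic carbon, here on a saturated chain carbon bound to an aromatic carbon, and the core is a different one.

Within the data shown here, the only precedent for adding a methyl to a chain is the downward step from compound 1 to compound 2. For compound 4 a smaller downward step is expected, a number 10 percentage points lower from compound 3 to compound 4 (within the scatter), because the starting point of compound 3 is already 50% and the place of the change is not the same. The estimate for compound 4 is 40%, with a range from 15% to 65%.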

Compound 4, a percentage reported as inhibition, in the whole organism at one dose (the size of the read-out at that dose, not a potency): 53%
Estimate against measurement, compound 4: 13 percentage points below, and the stated range covers the measured number.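

In this assay, adding a methyl to a saturated chain does not carry a single step size from one core to the other: the same change on two cores in this assay, a number 32 percentage points lower (beyond the scatter) from compound 1 to compound 2 and a number 3 percentage points higher (within the scatter) from compound 3 to compound 4, 35 percentage points apart, beyond the scatter of two such steps. The new step, a number 3 percentage points higher from compound 3 to compound 4 (within the scatter), shows that methyl to ethyl on the core of compound 3 stays within the scatter, so the large loss seen on the core of compound 1 cannot be assumed for every chain extension in this series. This does not show whether the core or the place of the methyl separates the two steps: the two pairs differ in both, with the methyl entering three bonds along the chain from an aromatic carbon in one and on a saturated chain carbon bound to an aromatic carbon in the other.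

Still open, from the compounds shown here alone, is whether a longer chain in place of the ethyl of compound 4 would keep the read-out level or turn it downward. The compounds shown also leave open how a hydroxyl or an amine on that chain would read at this single dose.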